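Removing the Methyl from the Hydrazone Aryl Oxygen

The compounds below may be only part of what the source reports. "The series", "measured", "known", "first", "only" and "open" are said of these compounds alone.

Compound 1 `COc1ccc(O)c(/C=N/NC(=O)c2ccc(-c3nc4ccccc4s3)cc2)c1` belongs to a small set of hydrazones sharing one core and tested in an assay on isolated protein for inhibition of Maltase-glucoamylase (Homo sapiens), with a stated time of 15 min; a lower number here means a stronger inhibitor, a higher number a weaker inhibitor. In that assay compound 1 gives 6500 nM. Compound 3 `O=C(N/N=C/c1ccc(F)c(Br)c1)c1ccc(-c2nc3ccccc3s2)cc1` gives 28000 nM in this assay, while compound 2 `O=C(N/N=C/c1cccnc1)c1ccc(-c2nc3ccccc3s2)cc1` is reported as "not active" (no number reported) in this assay, without a number. Among the two compounds with a number, compound 1 stands lowest; the only step on record is a 4.3-fold higher number from compound 1 to compound 3 (0.63 log units; beyond the scatter), a modest change that exchanges the whole aryl group on the carbon doubly bonded to nitrogen.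

Compound 4 `O=C(N/N=C/c1cc(O)ccc1O)c1ccc(-c2nc3ccccc3s2)cc1` has not yet been measured. It differs from compound 1 by hydrogen in place of methyl on an oxygen on an aromatic ring. Within the data shown here, no measured pair isolates this change, and the one recorded step concerns a different alteration, so it offers little direct guidance. Compound 1, which gives 6500 nM, therefore remains the anchor. Compound 4 is expected to stay close, with a step of no change at the digits printed from compound 1 to compound 4 (within the scatter) that does not leave the scatter. Compound 4 is estimated at 6500 nM in this assay, within a range from 2500 nM to 17000 nM.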

Compound 4, half-maximal inhibitory concentration: 11900 nM
Beside the measured number, compound 4's estimate is 1.8-fold (0.26 log units) below it, within the range that was stated.
By their numbers in this assay, from the lowest: compounds 1 and 4 (each within the scatter of the next); then compound 3.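

In this assay, among these compounds, the change from methoxy to hydroxy is seen on its own for the first time, and it gives a 1.8-fold higher number from compound 1 to compound 4 (0.26 log units; within the scatter). The methyl on this oxygen can therefore be exchanged for hydrogen without a step that leaves the scatter, so the two compounds cannot be ordered at this position. The 2,5-dihydroxyphenyl group also stands apart from the 3-bromo-4-fluorophenyl group, with a 2.4-fold lower number from compound 3 to compound 4 (0.37 log units; beyond the scatter), a modest step, and nothing measured here accounts for either step.

The compounds shown leave open how an ethyl or a longer chain on this oxygen would read in this assay. They also leave open whether an amine in place of the hydroxy would stay within the scatter of compound 1.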